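A few compounds are considered here, and "the series" means these few. Any claim that something is new, unique, unknown or untested is made for them only; others in the source may bear on it.

Measured so far:
compound 1 `COc1ccc(-c2nc(Cl)cc(Nc3ccc(NC(=O)CN4CCCC4)cc3)n2)cc1` — 18400 nM
compound 2 `COc1ccc(-c2nc(Cl)c(-c3ccccc3)c(Nc3ccc(NC(=O)CN4CCCC4)cc3)n2)cc1` — > 40000 nM

In a functional assay on Ishikawa cells (Homo sapiens) for antiproliferative activity, read by MTT assay, with a stated time of 48 h (on this read-out lower numbers stand for stronger inhibition and higher numbers for weaker inhibition), compound 1 gives 18400 nM. For compound 2 this assay reports only a limit, > 40000 nM, and no number; this is the limit of > 40000 nM in this assay, at which 1 of the 2 values shown sits. Among the measured compounds shown here, the single measured step, an at least 2.1-fold higher number from compound 1 to compound 2 (0.33 log units; beyond the scatter), concerns phenyl in place of hydrogen on an aromatic carbon and therefore does not bear on the next change. Compound 3 `COc1ccc(-c2nc(Cl)c(-c3ccccc3)c(Nc3ccc(NC(=O)CN(C)C)cc3)n2)cc1` differs from compound 2 as follows: dimethylamino in place of pyrrolidin-1-yl on a saturated chain carbon bound to a carbonyl carbon. For the measured compounds named here, no measured step covers this exchange, so no shift beyond the scatter is expected, meaning an estimated step that the limit leaves unreadable from compound 2 to compound 3. In this assay compound 3 is expected near 50000 nM, within 20000 nM to 120000 nM.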

Compound 3, half-maximal inhibitory concentration: 17100 nM
Beside the measured number, compound 3's estimate is 2.9-fold (0.47 log units) above it; measured number below the stated range.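

In this assay, dimethylamino in place of pyrrolidin-1-yl on a saturated chain carbon bound to a carbonyl carbon gives an at least 2.3-fold lower number from compound 2 to compound 3 (0.36 log units; beyond the scatter). This place in the chain therefore answers to the exchange, which the earlier step, made on an aromatic carbon, could not show. The full size of the step stays unknown, as compound 2 has a limit and not a number: the limit of > 40000 nM in this assay, at which 1 of the 3 values shown sits.

Open, as far as these compounds go, is whether diethylamino or morpholin-4-yl at this place, or a longer chain before the amine, moves the number further. Also open, from the compounds shown here alone, is whether the same exchange holds on the core of compound 1, which lacks the phenyl.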